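The compounds below may be only part of what the source reports. "The series", "measured", "known", "first", "only" and "open" are said of these compounds alone.

In a functional assay on DU-145 cells (Homo sapiens) for cytotoxicity, read by trypan blue exclusion, with a stated time of 96 h (on this read-out lower numbers stand for stronger inhibition and higher numbers for weaker inhibition), compound 1 `COC(=O)CNc1cc(CS(=O)(=O)/C=C/c2c(OC)cc(OC)cc2OC)ccc1OC` gives 100 nM, compound 2 `COC(=O)C(Nc1cc(CS(=O)(=O)/C=C/c2c(OC)cc(OC)cc2OC)ccc1OC)c1ccc(Cl)cc1` gives 400 nM and compound 3 `COC(=O)C(Nc1cc(CS(=O)(=O)/C=C/c2c(OC)cc(OC)cc2OC)ccc1OC)c1ccc(OC)cc1` gives 250 nM. Compound 2 therefore shares the high end of these numbers with compound 3, and it stands clearly apart from compound 1, as shown by a 4.0-fold higher number from compound 1 to compound 2 (0.60 log units; beyond the scatter). Compound 4 `COc1cc(OC)c(/C=C/S(=O)(=O)Cc2ccc(OC)c(NC(C(=O)O)c3ccc(F)cc3)c2)c(OC)c1` carries carboxy(4-fluorophenyl)methyl in place of (4-chlorophenyl)(methoxycarbonyl)methyl on the nitrogen: carboxy(4-fluorophenyl)methyl in place of (4-chlorophenyl)(methoxycarbonyl)methyl on a nitrogen on an aromatic ring. The closest guide is the change on the aromatic carbon in compound 3, which gave a 1.6-fold lower number from compound 2 to compound 3 (0.20 log units; within the scatter). Among the compounds with values here, no measured step isolates the carboxy group or the fluoro group, so the uncertainty is wide. No step beyond the scatter is expected in this assay, and the estimated step is a 1.1-fold lower number from compound 2 to compound 4 (0.06 log units; within the scatter). The expected value for compound 4 is 350 nM, with an estimated range of 100 nM to 1200 nM.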

Compound 4, half-maximal inhibitory concentration: 150 nM
The estimate for compound 4 lay 2.3-fold (0.37 log units) above the measured number; the range from low to high includes it.
By their numbers in this assay, from the lowest: compounds 1, 4, 3 and 2 (each within the scatter of the next, the first and the last beyond it).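

Changing the group on the nitrogen on an aromatic ring gives a 2.7-fold lower number from compound 2 to compound 4 (0.43 log units; beyond the scatter), which shows that a group carrying an aromatic ring at this position need not keep the number as high as in compound 2. With a 1.5-fold higher number from compound 1 to compound 4 (0.18 log units; within the scatter), the carboxy(4-fluorophenyl)methyl group also stays level with the simpler (methoxycarbonyl)methyl group, although both earlier additions of a substituted phenyl ring raised the number. No available evidence explains this result.

Going by these compounds, the carboxy group and the fluoro group enter together, and their separate shares of the step remain open. Also open, on these data alone, is how an amide or a tetrazole would behave in this place.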